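The source may report more compounds than this note shows. Statements on the series, on what has been measured and on what is new or still open speak of the compounds shown alone.

Measured compounds in an assay on isolated protein for inhibition of thiosulfate sulfurtransferase (Homo sapiens), with a stated time of 60 min, in the absence of a further agent; a higher number here means a weaker inhibitor, a lower number a stronger inhibitor:

compound 1, `COc1c(Br)cc(Br)cc1C(=O)Nc1ccccc1` — > 100000 nM, a limit of the assay and not a number.
compound 2, `COc1c(Br)cccc1C(=O)Nc1ccccc1` — > 100000 nM, likewise a limit and not a number.
compound 3, `O=C(Nc1cccc(Cl)c1)c1cc(Br)cc(Br)c1` — > 100000 nM, again only a limit.

All three values sit at the limit of > 100000 nM in this assay, at which 3 of the 3 values shown sit; no numerical potency is known for any of them. Compound 2 differs from compound 1 by hydrogen in place of bromo on an aromatic carbon. The step that the two limits leave unreadable from compound 1 to compound 2 cannot be read; both of its ends are limits. How the core of compound 3 differs from the core of compound 1 is not broken down here; only what compound 3 shows stands on its own, and that is a limit.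

Compound 4, `O=C(Nc1cccc(Cl)c1)c1cccc(Br)c1`, is not yet measured. It differs from compound 3 by hydrogen in place of bromo on an aromatic carbon. This is the same kind of change as that from compound 1 to compound 2, but not the same change: in compound 1 the place is meta to a bromo group (1 heavy atom), meta to a group of 9 heavy atoms and para to a methoxy group (2 heavy atoms), whereas in compound 3 it is meta to a bromo group (1 heavy atom) and meta to a large group.

In this assay the step from compound 3 to compound 4 is expected to be a step that the limit leaves unreadable from compound 3 to compound 4; this expectation rests on the unreadable step that the two limits leave unreadable from compound 1 to compound 2 and on compound 3 sitting at the limit of > 100000 nM in this assay, at which 3 of the 3 values shown sit. Compound 4 is expected at 150000 nM in this assay, with a range from 40000 nM to 600000 nM, and most probably reported once more only as a limit.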

Compound 4, half-maximal inhibitory concentration: > 100000 nM
Compound 4 gave a limit, no number; the forecaster's own chance of this, stated with the estimate: 85%; the middle value lies beyond the limit too.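

In this assay compound 4 gives > 100000 nM, a limit and not a number. Going by these compounds alone, with compound 3 also at a limit, the step between compound 3 and compound 4 cannot be read, so no new step emerges. The compounds shown leave open whether hydrogen in place of bromo on an aromatic carbon alters inhibition at all, and what numerical potency any of them has: the limit of > 100000 nM in this assay, at which 4 of the 4 values shown sit.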